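Methyl on the amine nitrogen of compound 3

The source may report more compounds than this note shows. Statements on the series, on what has been measured and on what is new or still open speak of the compounds shown alone.

Measured so far in an ADME assay on CHO cells (Cricetulus griseus) for cytotoxicity, read by MTT assay; a higher number here means that more compound is tolerated, a lower number that less compound is tolerated:

- compound 1 `Fc1ccc(-c2nc3c(N4CCNCC4)nccc3[nH]2)cc1F`: 8100 nM
- compound 2 `Fc1ccc(-c2nc3c(N4CCN5CCCC5C4)nccc3[nH]2)cc1F`: 32000 nM
- compound 3 `C[C@@H]1CN(c2nccc3[nH]c(-c4ccc(F)c(F)c4)nc23)C[C@H](C)N1`: 6500 nM

Among these three, compound 3 and compound 1 stand level within the usual scatter of repeated measurements. Compound 2, at 32000 nM, clearly tolerates more, and its gap to compound 3 lies beyond that scatter.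

The next compound, compound 4 `C[C@@H]1CN(c2nccc3[nH]c(-c4ccc(F)c(F)c4)nc23)C[C@H](C)N1C`, differs from compound 3 in one place. It has methyl in place of hydrogen on an amine nitrogen in a ring. Among the compounds with values here, only one measured step links two compounds that differ in one place: a 1.2-fold lower number from compound 1 to compound 3 (0.10 log units; within the scatter). That step exchanges piperazin-1-yl for 3,5-dimethylpiperazin-1-yl on an aromatic carbon, so it also adds methyl groups, but not on this nitrogen. Within the data shown here, it is therefore only an indirect guide, and no measurement yet shows the new change itself.

Among the measured compounds shown here, with that small step as the sole guide, no change beyond the scatter is expected in this assay. The expected step is a 1.1-fold higher number from compound 3 to compound 4 (0.03 log units; within the scatter). For compound 4 the estimated value is 7000 nM, with an expected range of 3500 nM to 16000 nM.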

Compound 4, half-maximal cytotoxic concentration: > 50000 nM
Compound 4 was reported as a limit (the forecaster's own chance of this, stated with the estimate: 3%); at least 7.1-fold (0.85 log units) between middle value and limit.
By their numbers in this assay, from the lowest: compounds 3 and 1 (each within the scatter of the next); then compound 2. At a limit, above all of these: compound 4.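

In this assay, methyl in place of hydrogen on an amine nitrogen in a ring gives an at least 7.6-fold higher number from compound 3 to compound 4 (0.88 log units; beyond the scatter), so a single added carbon on this nitrogen matters here, whereas the methyl groups added elsewhere on the ring gave only a 1.2-fold lower number from compound 1 to compound 3 (0.10 log units; within the scatter). Compound 4 gives > 50000 nM, which is a limit and not a number. The step therefore shows the direction of the change and a smallest size for it, but not its full size, because the reading for compound 4 stops at this limit: the limit of > 50000 nM in this assay, at which 1 of the 4 values shown sits.

The compounds shown leave open whether this shift belongs to methyl alone or would also follow from another group on the same nitrogen, such as an ethyl group, an acetyl group or a longer chain. They also leave open whether methyl on the nitrogen of the piperazin-1-yl group of compound 1 would act in the same way, since the change is seen here only with the nitrogen next to two ring atoms that each bear a methyl group.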